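This account rests on a few compounds, and the source may have more. Where it says the series, first, only, none or still open, it means among the compounds named here.

Compound 1 `COc1ccc([C@@H]2CCc3c(OC)cc(OC)cc3O2)cc1` — 29000 nM
Compound 2 `COc1cc(-c2coc3cc(O)cc(O)c3c2=O)ccc1O` — 68000 nM
Compound 3 `COc1cc(OC)c2c(c1)O[C@H](c1ccc(O)cc1)CC2` — 39000 nM

In a functional assay on U-937 cells (Homo sapiens) for antiproliferative activity, read by WST assay, with a stated time of 24 h (on this read-out higher numbers stand for weaker inhibition and lower numbers for stronger inhibition), compound 1 gives 29000 nM, the lowest of the three numbers. Compound 3 gives 39000 nM, and the step of a 1.3-fold higher number from compound 1 to compound 3 (0.13 log units; within the scatter) lies within the scatter, so the two numbers cannot be told apart. Compound 2, with a different core, gives 68000 nM, a number beyond the scatter from compound 1.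

Compound 4 `COc1ccc([C@@H]2CCc3c(OC)cc(OC)cc3O2)c(O)c1` keeps the core of compound 1 and differs from it in one place: hydroxy in place of hydrogen on an aromatic carbon. Within the data shown here, no measured pair shows a hydroxy entering where a hydrogen stood; the only measured step on the shared core, a 1.3-fold higher number from compound 1 to compound 3 (0.13 log units; within the scatter), swaps a methyl for a hydrogen on an oxygen and moves the number by less than the scatter. With nothing more to go on, the step from compound 1 to compound 4 is expected to be a 1.0-fold higher number from compound 1 to compound 4 (0.01 log units; within the scatter), that is, no step beyond the scatter. Compound 4 is therefore estimated at 30000 nM, with a range from 12000 nM to 75000 nM.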

Compound 4, half-maximal inhibitory concentration: 37000 nM
Compound 4: middle estimate off by 1.2-fold (0.09 log units), on the low side, within the range that was stated.
By their numbers in this assay, from the lowest: compounds 1, 4, 3 and 2 (each within the scatter of the next, the first and the last beyond it).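

In this assay, hydroxy in place of hydrogen on an aromatic carbon, ortho to a large group and meta to a methoxy group, gives a 1.3-fold higher number from compound 1 to compound 4 (0.11 log units; within the scatter), so compound 1 and compound 4 cannot be told apart. The earlier step on the shared core concerned only a methyl on an oxygen, whereas this one shows that a hydroxy can enter on an aromatic carbon at this position with no shift beyond the scatter. No measurement given here accounts for this result.

The compounds shown leave open whether an amine or a carboxylic acid on this aromatic carbon would give a number beyond the scatter from compound 1. They also leave open whether a hydroxy on another aromatic carbon of the shared core would behave as it does in compound 4.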